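A Bromo-to-Methyl Swap Assessed for Cytotoxicity

The compounds below may be only part of what the source reports. "The series", "measured", "known", "first", "only" and "open" are said of these compounds alone.

Of the compounds shown here, two sharing one core have been measured so far. Compound 1 `O=C(CSc1ncccn1)N/N=c1/scc(-c2ccc(Br)cc2)n1-c1ccccc1` was tested in a functional assay on C6 cells (Rattus norvegicus) for cytotoxicity, read by MTT assay, with a stated time of 24 h, tested at 200 ug/mL (on this read-out lower numbers stand for a stronger effect and higher numbers for a weaker effect at the one concentration tested), and gave 63.2%. Compound 2 `Cn1cnnc1SCC(=O)N/N=c1/scc(-c2ccc(C#N)cc2)n1-c1ccccc1` gave 52.6% in this assay. Of the two numbers, compound 1 stands highest, and compound 2 is its nearest neighbour, lying lower by a margin beyond the usual scatter. Compound 2 differs from compound 1 in more than one place, so nothing more can be said of that pair than what the two values show.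

The account follows the step from compound 1 to compound 3 `Cc1ccc(-c2cs/c(=N/NC(=O)CSc3ncccn3)n2-c2ccccc2)cc1`, which has not yet been measured in this assay. The change is methyl in place of bromo on an aromatic carbon, the 4-bromophenyl of compound 1 becoming 4-methylphenyl. For the measured compounds named here, no measured pair in this set isolates such a change, so there is no step to lean on. In this assay the step is expected to be small, not beyond the scatter, in either direction. For compound 3 the expected step is a number 1.8 percentage points higher from compound 1 to compound 3 (within the scatter). Compound 3 is estimated to give 65% in this assay, within a range from 45% to 85%.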

Compound 3, a percentage reported as activity, at one concentration (the size of the read-out at that concentration, not a potency): 43.7%
The estimate for compound 3 lay 21.3 percentage points above the measured number, and the stated range ends above it.
By their numbers in this assay, from the lowest: compounds 3 and 2 (each within the scatter of the next); then compound 1.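

For the compounds shown here, the step of a number 19.5 percentage points lower from compound 1 to compound 3 (beyond the scatter) in this assay is the first single-place comparison in this set, and it shows that this aromatic carbon, para to a large group, is not a silent position: methyl in place of bromo moves the read-out beyond the scatter, towards the stronger effect at the one concentration tested. The change is a minimal one, a single heavy atom leaving and a single heavy atom entering, with no ring, hydrogen-bond donor, hydrogen-bond acceptor or net charge involved on either side, yet that alone is enough to shift the result. Nothing available here accounts for the direction or the size of this step.

Going by these compounds, what an amine, a carboxylic acid or a longer chain such as propyl would give on this same aromatic carbon remains open, so the two groups compared here do not yet describe a trend at this position. Going by these compounds alone, it is also open whether methyl in place of bromo would produce a similar step on a compound carrying a different group at the other end of the molecule, such as the one found in compound 2.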